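Swapping the amide-nitrogen aryl group in a weak series

The source may report more compounds than this note shows. Statements on the series, on what has been measured and on what is new or still open speak of the compounds shown alone.

Compound 1, `COc1cccc(N2C(=O)COc3ccc(-c4cnc(Cl)c(NS(=O)(=O)c5ccc(F)cc5)c4)cc32)c1`, is tested in a functional assay on HeLa cells (Homo sapiens) for antiproliferative activity, read by MTT assay, with a stated time of 72 h; a lower number here means a stronger inhibitor, a higher number a weaker inhibitor. Its result there is a limit of the assay rather than a number: in this assay compound 1 gives > 40000 nM. Compound 2, `O=C1COc2ccc(-c3ccc(O)cc3)cc2N1`, shares part of the core and is also reported only as a limit, compound 2 giving > 40000 nM in this assay. Both reported values therefore sit at the same edge, which is summarised as the limit of > 40000 nM in this assay, at which 2 of the 2 values shown sit. Compound 1 thus stands at the weak end of what the assay can report, with no number to separate it from compound 2.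

Compound 3, `Cc1ccc(N2C(=O)COc3ccc(-c4cnc(Cl)c(NS(=O)(=O)c5ccc(F)cc5)c4)cc32)cc1`, is the next compound to be measured. It differs from compound 1 in one place: 4-methylphenyl in place of 3-methoxyphenyl on an amide-type nitrogen in a ring. For the measured compounds named here, no step between measured compounds exists to guide the size of this change. With both reported values resting at the limit, compound 3 is expected to remain at or near that edge, so the estimated step is a step that the limit leaves unreadable from compound 1 to compound 3, which would be none beyond the scatter. Compound 3 is estimated at 50000 nM in this assay, with a range from 15000 nM to 200000 nM.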

Compound 3, half-maximal inhibitory concentration: 32300 nM
Compound 3: middle estimate off by 1.5-fold (0.19 log units), on the high side; the measured number falls inside the stated range.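

With 4-methylphenyl in place of 3-methoxyphenyl on the amide-type nitrogen in a ring, this assay yields a number rather than a limit, and compound 3 is the only compound shown to do so, giving 32300 nM. The change amounts to an at least 1.2-fold lower number from compound 1 to compound 3 (0.09 log units; that floor lies within the scatter), so this position is not yet shown to shift the value beyond the scatter, although the printed step is only a floor and the real difference could be larger. The series as shown also remains close to the weak edge of what can be reported, with most of its values resting at that edge: the limit of > 40000 nM in this assay, at which 2 of the 3 values shown sit.

The compounds shown leave open how far compound 3 really lies from compound 1, whose result is only a limit, and whether any group on this nitrogen can bring the value well clear of that edge. They also do not tell whether the swap of the methoxy group for the methyl group or the move around the phenyl ring matters more, or how a 4-methoxyphenyl, a pyridine ring or a short alkyl chain would read at this place.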